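Trifluoromethyl compound 3 and its aminomethyl analogue

A few compounds are considered here, and "the series" means these few. Any claim that something is new, unique, unknown or untested is made for them only; others in the source may bear on it.

Measured values:
- compound 1 `O=C(O)c1cn(C2CC2)c2cc(N3CCCC3)c(F)cc2c1=O`: 38 ug/mL
- compound 2 `O=C(O)c1cn(C2CC2)c2c(F)c(N3CCCC3)c(F)cc2c1=O`: 120 ug/mL
- compound 3 `O=C(O)c1cn(C2CC2)c2c(C(F)(F)F)c(N3CCCC3)c(F)cc2c1=O`: 280 ug/mL

All three values come from a functional assay on V79 cells (Cricetulus griseus) for cytotoxicity, read by colony formation; a higher number here means a weaker inhibitor, a lower number a stronger inhibitor. Compound 3 has the highest number of the three, and its gap to the others is shown by a 2.3-fold higher number from compound 2 to compound 3 (0.37 log units; beyond the scatter) and a 7.4-fold higher number from compound 1 to compound 3 (0.87 log units; beyond the scatter). The next compound, compound 4 `NCC1CCN(c2c(F)cc3c(=O)c(C(=O)O)cn(C4CC4)c3c2C(F)(F)F)C1`, keeps the trifluoromethyl group and changes pyrrolidin-1-yl to 3-(aminomethyl)pyrrolidin-1-yl: aminomethyl in place of hydrogen on a saturated ring carbon. Among the compounds with values here, no measured step touches this saturated ring, so the evidence is indirect. The steps on an aromatic carbon, a 3.2-fold higher number from compound 1 to compound 2 (0.50 log units; beyond the scatter) and a 7.4-fold higher number from compound 1 to compound 3 (0.87 log units; beyond the scatter), are all modest and give only a scale of size. Since compound 3 at 280 ug/mL sits at the top of the series, a modest move to a lower number is expected, with low confidence in its direction. For compound 4 the estimated step is a 2.3-fold lower number from compound 3 to compound 4 (0.37 log units; beyond the scatter). Compound 4 is estimated at 120 ug/mL, with an expected range of 35 ug/mL to 400 ug/mL.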

Compound 4, half-maximal inhibitory concentration: 38 ug/mL
The estimate for compound 4 lay 3.2-fold (0.50 log units) above the measured number, within the range that was stated.
By their numbers in this assay, from the lowest: compounds 1 and 4 (each within the scatter of the next); then compound 2; then compound 3.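

In this assay, within the data shown here, the saturated ring carbon, two ring bonds from the ring nitrogen, proves responsive: with trifluoromethyl kept, aminomethyl in place of hydrogen gives a 7.4-fold lower number from compound 3 to compound 4 (0.87 log units; beyond the scatter), the first change to lower the number. This step is equal in size and opposite in direction to the one that introduced trifluoromethyl on the aromatic carbon, a 7.4-fold higher number from compound 1 to compound 3 (0.87 log units; beyond the scatter), so a change on the saturated ring can offset that earlier rise. Nothing available explains this shift.

From the compounds shown here alone, whether aminomethyl gives a step of this size with hydrogen or fluoro in place of trifluoromethyl remains open. Also open, going by these compounds, is whether hydroxymethyl or a longer aminoethyl chain on the same ring carbon would move the number in the same direction.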